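Chromone series: removal of the chloro substituent

A few compounds are considered here, and "the series" means these few. Any claim that something is new, unique, unknown or untested is made for them only; others in the source may bear on it.

Measured so far in a functional assay on MDA-MB-435S cells (Homo sapiens) for cytotoxicity, read by MTT assay, with a stated time of 72 h; on this read-out higher numbers stand for weaker inhibition and lower numbers for stronger inhibition:
compound 1 `Cc1nnc(SCc2coc3ccc(Cl)cc3c2=O)o1` gives 3300 nM
compound 2 `Cc1nnc(SCc2coc3ccc(Cl)cc3c2=O)s1` gives 2200 nM
compound 3 `Cc1ccc2oc(CSc3nnc(N)s3)cc(=O)c2c1` gives only a limit, > 25000 nM

Compound 2 stands at the lowest of the two numbers in this assay; the nearest is compound 1, and the step of a 1.5-fold lower number from compound 1 to compound 2 (0.18 log units; within the scatter) lies within the scatter. The value of compound 3 is a limit of the assay, not a number (the limit of > 25000 nM in this assay, at which 1 of the 3 values shown sits).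

Compound 4 `Cc1nnc(SCc2coc3ccccc3c2=O)s1` is not yet measured. It differs from compound 2 in one place: hydrogen in place of chloro on an aromatic carbon. For the measured compounds named here, the only measured step, a 1.5-fold lower number from compound 1 to compound 2 (0.18 log units; within the scatter), concerns the heterocycle on the sulfur and says nothing about the chloro substituent; no measured pair shows removal of that group. The expectation therefore rests on compound 2 alone, at 2200 nM, and takes the change as neutral with a wide margin. Compound 4 is estimated at 3500 nM, between 1200 nM and 12000 nM, a step of a 1.6-fold higher number from compound 2 to compound 4 (0.20 log units; within the scatter) from compound 2 expected to stay within the scatter.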

Compound 4, half-maximal inhibitory concentration: 630 nM
For compound 4 the middle estimate is 5.6-fold (0.74 log units) above the measured one, and the stated range ends above it.
By their numbers in this assay, from the lowest: compound 4; then compounds 2 and 1 (each within the scatter of the next). At a limit, above all of these: compound 3.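

In this assay hydrogen in place of chloro on an aromatic carbon gives a 3.5-fold lower number from compound 2 to compound 4 (0.54 log units; beyond the scatter) and this is the only step shown that lies beyond the scatter. The chloro substituent at this position is therefore not required for activity in this pair, and its removal matters more here than the change of heterocycle on the sulfur, which stayed within the scatter. The data shown give no reason for this step.

Going by these compounds, the result rests on a single pair, so it remains open whether removing chloro has the same effect with 5-methyl-1,3,4-oxadiazol-2-yl on the sulfur. On these data alone, it also remains open how a fluoro, a methoxy or an amine at this position would compare with hydrogen and chloro.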